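A few compounds are considered here, and "the series" means these few. Any claim that something is new, unique, unknown or untested is made for them only; others in the source may bear on it.

Measured compounds:
- Compound 1 `Cc1ccc(-n2nc(C(=O)Nc3ccc(Oc4ncnc5ccsc45)cc3)c(C)cc2=O)cc1`, giving in a functional assay on MCF7 cells (Homo sapiens) for cytotoxicity, read by MTT assay, with a stated time of 72 h (on this read-out higher numbers stand for weaker inhibition and lower numbers for stronger inhibition), a value of 23800 nM.
- Compound 2 `Cc1cc(=O)n(-c2ccc(F)c(F)c2)nc1C(=O)Nc1ccc(Oc2ncnc3ccsc23)cc1`, giving in this assay a value of 5550 nM.
- Compound 3 `Cc1ccc(-n2nc(C(=O)Nc3ccc(Oc4ncnc5ccsc45)cc3)c(C)cc2=O)c(C)c1`, giving in this assay a value of 11900 nM.

Among these three, compound 2 shows the lowest number; the step of a 4.3-fold lower number from compound 1 to compound 2 (0.63 log units; beyond the scatter) and the step of a 2.1-fold higher number from compound 2 to compound 3 (0.33 log units; beyond the scatter) both lie beyond the scatter, so compound 2 stands as the strongest inhibitor of the three. The step of a 2.0-fold lower number from compound 1 to compound 3 (0.30 log units; within the scatter) stays within the scatter.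

Compound 4 `Cc1cc(=O)n(-c2ccc(F)c(F)c2)nc1C(=O)Nc1ccc(Oc2ncnc3ccsc23)c(F)c1` differs from compound 2 in one place: fluoro in place of hydrogen on an aromatic carbon. Among the measured compounds shown here, this change sits on the ring bearing the amide nitrogen, a part of the molecule that none of the measured steps touches; those steps alter only the group on the aromatic nitrogen. The closest comparison is the step of a 2.0-fold lower number from compound 1 to compound 3 (0.30 log units; within the scatter), where a small group entered on an aromatic carbon and the number stayed within the scatter. On that basis no step beyond the scatter is expected in this assay for compound 4, and the expected change from compound 2 is a 1.1-fold lower number from compound 2 to compound 4 (0.05 log units; within the scatter). Compound 4 is therefore estimated at 5000 nM, with a range from 1800 nM to 14000 nM.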

Compound 4, half-maximal inhibitory concentration: 6900 nM
Estimate against measurement, compound 4: 1.4-fold (0.14 log units) below; the range from low to high includes it.
By their numbers in this assay, from the lowest: compounds 2, 4, 3 and 1 (each within the scatter of the next, the first and the last beyond it).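

In this assay, fluoro in place of hydrogen on an aromatic carbon of a six-membered aromatic ring of carbon only, ortho to a large group and meta to a large group, gives a 1.2-fold higher number from compound 2 to compound 4 (0.09 log units; within the scatter). Among the compounds shown here, this is the first measured change outside the group on the aromatic nitrogen, and it shows that this carbon of the ring can carry a fluoro group without a shift that can be told from the scatter, so the read-out gives no sign here that the hydrogen at this position is needed. The data offer no measurement that could account for this flat result, so it stands as an observation without an explanation.

The compounds shown leave open whether this tolerance extends to something larger or very different at the same carbon, such as a methoxy group, an amine or a carboxylic acid. For the compounds shown here, they also leave open whether fluoro at this carbon would behave the same way with the 4-methylphenyl group of compound 1 on the aromatic nitrogen, since the change is seen only with the 3,4-difluorophenyl group.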